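The source may report more compounds than this note shows. Statements on the series, on what has been measured and on what is new or still open speak of the compounds shown alone.

Measured so far:
- Compound 1 `COC(=O)C1=C(C)NC(=O)NC1c1ccoc1`: 42%
- Compound 2 `COC(=O)C1=C(C)NC(=O)NC1c1cccs1`: 19%
- Compound 3 `COC(=O)C1=C(C)N(C)C(=O)NC1c1ccoc1`: 7%

In an assay on membranes from HEK293 cells for displacement of a labelled ligand from adenosine receptor A2b (Homo sapiens), read by scintillation counting, with a stated time of 30 min, tested at 1 uM (on this read-out higher numbers stand for more inhibition at the one concentration tested (going by the name of the read-out) and lower numbers for less inhibition), compound 1 gives the highest of the three numbers. Replacing its furan-3-yl on a saturated ring carbon with thiophen-2-yl gives compound 2, and a number 23 percentage points lower from compound 1 to compound 2 (beyond the scatter). Replacing hydrogen with methyl on an amide-type nitrogen in the ring of compound 1 gives compound 3, and a number 35 percentage points lower from compound 1 to compound 3 (beyond the scatter). Both changes to compound 1 thus brought the read-out down, one modestly and one by a large margin.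

Compound 4 `CC(=O)C1=C(C)NC(=O)NC1c1ccoc1` is yet to be measured. It differs from compound 1 only at the carbonyl carbon: methyl in place of methoxy on a carbonyl carbon. Neither measured step touches this position; one concerns the aromatic ring on the saturated ring carbon, the other the ring nitrogen. Among the measured compounds shown here, there is therefore no direct precedent for this step, and the two measured steps only show that each change to compound 1 so far has given a lower number.

With that in mind, the number for compound 4 is estimated at 30%, with a range of 5% to 55%. This would mean an expected step of a number 12 percentage points lower from compound 1 to compound 4 (beyond the scatter), a drop that could yet fall within the scatter.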

Compound 4, a percentage reported as inhibition, at one concentration (the size of the read-out at that concentration, not a potency): 15%
The estimate for compound 4 lay 15 percentage points above the measured number; measured number inside the range.
By their numbers in this assay, from the lowest: compounds 3, 4 and 2 (each within the scatter of the next, the first and the last beyond it); then compound 1.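

Methoxycarbonyl to acetyl is the first change at the carbonyl carbon, and it shows that this position also matters in this assay: methyl in place of methoxy gives a clear drop (a number 27 percentage points lower from compound 1 to compound 4 (beyond the scatter)). Changes at three separate places on compound 1 have now all lowered the number, and none of the compounds shown goes against this, so compound 1 remains the highest of the four. The change swaps a group counted with one hydrogen-bond acceptor for a smaller group counted with none, but no measurement here explains why the number falls.

A single swap cannot separate the loss of the oxygen from the loss of a heavy atom, as both change together between compound 1 and compound 4. The compounds shown leave open what a longer chain such as ethoxy, an amine or a hydroxyl on the same carbonyl carbon, which would give an amide or a carboxylic acid, would do to the number.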